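A few compounds are considered here, and "the series" means these few. Any claim that something is new, unique, unknown or untested is made for them only; others in the source may bear on it.

Working notes on the series. Compound 1 `O=C(O)[C@H]1C2CCC(CC2)[C@@H]1Nc1nc(-c2c[nH]c3ncc(F)cc23)nc2cccc(F)c12`, compound 2 `Cc1cnc2c(N[C@H]3C4CCC(CC4)[C@@H]3C(=O)O)nc(-c3c[nH]c4ncc(F)cc34)nc2c1` and compound 3 `Cc1cccc2nc(-c3c[nH]c4ncc(F)cc34)nc(N[C@H]3C4CCC(CC4)[C@@H]3C(=O)O)c12` have been tested in an ADME assay on MDCK cells (Canis lupus familiaris) for cytotoxicity, read by CCK-8 assay, with a stated time of 5 days; a higher number here means that more compound is tolerated, a lower number that less compound is tolerated; compound 4 `O=C(O)[C@H]1C2CCC(CC2)[C@@H]1Nc1nc(-c2c[nH]c3ncc(F)cc23)nc2cc(F)cnc12` has not. In this assay compound 1 gives 1800 nM, compound 2 gives 4900 nM and compound 3 gives 4700 nM. Compound 2 and compound 3 lie within the scatter of each other, while compound 1 is the furthest from compound 2. The difference between the core of compound 2 and the core of compound 3 is not broken down here.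

Compound 1 arises from compound 3 by fluoro in place of methyl on an aromatic carbon. Compound 4 arises from compound 2 by fluoro in place of methyl on an aromatic carbon. This is the same kind of change, not the same one: in compound 1 the site is in a ring of carbon only, ortho to a fused ring and meta to a fused ring, whereas in compound 4 the ring holds one nitrogen and the site is two atoms from the ring nitrogen, meta to a fused ring and para to a fused ring.

Among the compounds with values here, for compound 4 a step of roughly the same size, a 2.3-fold lower number from compound 2 to compound 4 (0.37 log units; beyond the scatter), is expected in this assay, because the one measured instance of this change, a 2.6-fold lower number from compound 3 to compound 1 (0.42 log units; beyond the scatter), is modest but beyond the scatter; the single example and the changed surroundings keep the expectation loose. Compound 4 is therefore estimated at 2100 nM, between 900 nM and 5000 nM.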

Compound 4, half-maximal cytotoxic concentration: 1400 nM
Beside the measured number, compound 4's estimate is 1.5-fold (0.18 log units) above it, within the range that was stated.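

In this assay, fluoro in place of methyl on an aromatic carbon gives a 3.5-fold lower number from compound 2 to compound 4 (0.54 log units; beyond the scatter), a modest step. Set beside the earlier step, the change carries over from one core to the other, in the same direction and with no difference in size that can be told apart: the same change on two cores in this assay, a 2.6-fold lower number (0.42 log units; beyond the scatter) from compound 3 to compound 1 and a 3.5-fold lower number (0.54 log units; beyond the scatter) from compound 2 to compound 4, 1.3-fold (0.13 log units) apart, within the scatter of two such steps This agreement rests on two pairs only, one with the site in a ring of carbon only and one with the site in a ring with 1 nitrogen; it does not show that the step would hold on any further core, and it does not show what sets its size.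

The compounds shown leave open whether another group on the same aromatic carbon, such as chloro, methoxy or a nitrile, would give a step of similar size. They also leave open whether the step would persist if an amide stood in place of the carboxylic acid shared by all four compounds.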